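Chain extension on compound 2 with a trifluoroethyl terminus

The source may hold more compounds than are shown below. What is called first, only, known or untested is meant among the compounds shown, and "the series" means these compounds.

In an assay on HEK293 cells for inhibition of solute carrier family 12 member 2 (Homo sapiens), read by fluorescence, with a stated time of 30 min, tested at 100 uM (on this read-out lower numbers stand for a weaker effect and higher numbers for a stronger effect at the one concentration tested), compound 1 `CCCCNc1ccc([N+](=O)[O-])cc1S(=O)(=O)N(C)C` gives 15.2% and compound 2 `CCCCNc1ccc(C(=O)O)cc1S(=O)(=O)N(C)C` gives 15.6%. Compound 2 sits level with compound 1: the step of a number 0.4 percentage points higher from compound 1 to compound 2 (within the scatter) lies within the scatter. Compound 3 `CN(C)S(=O)(=O)c1cc(C(=O)O)ccc1NCCCCCC(F)(F)F` differs from compound 2 by 2,2,2-trifluoroethyl in place of hydrogen on a saturated chain carbon, four bonds along the chain from a nitrogen on an aromatic ring. Going by the values given here, no measured step touches the chain; the one step known concerns the aromatic substituent and was within the scatter, so no direction can be read from it. For compound 3 in this assay the expectation is a step of a number 4.4 percentage points higher from compound 2 to compound 3 (within the scatter) of modest size and uncertain direction. Compound 3 is estimated at 20%, between 5% and 40%.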

Compound 3, a percentage reported as inhibition, at one concentration (the size of the read-out at that concentration, not a potency): 12.6%
For compound 3 the middle estimate is 7.4 percentage points above the measured one, within the range that was stated.
By their numbers in this assay, from the lowest: compounds 3, 1 and 2 (each within the scatter of the next).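

In this assay, the chain gives its first reading: 2,2,2-trifluoroethyl in place of hydrogen on a saturated chain carbon, four bonds along the chain from a nitrogen on an aromatic ring, gives a number 3 percentage points lower from compound 2 to compound 3 (within the scatter). This position therefore takes the 5 added heavy atoms without a step beyond the scatter, as did the carboxy-for-nitro change at the aromatic carbon. No measurement shown accounts for this result. Still open, going by these compounds, is whether an amine or a carboxylic acid at the chain end, or a shorter chain, would give a step beyond the scatter.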